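Swapping the Acetamido Chain for an Aminocyclopentyl Ring

The source may report more compounds than this note shows. Statements on the series, on what has been measured and on what is new or still open speak of the compounds shown alone.

The measured compounds in a functional assay for agonist activity at G protein-coupled receptor 88 (Homo sapiens), read by HTRF and cAMP accumulation; on this read-out higher numbers stand for an effect only at larger amounts of compound and lower numbers for an effect already at smaller amounts:
compound 1 `CC(C)C[C@H](N)CN(C(=O)C(C)Cc1ccccc1)c1ccc(-c2ccccc2)cc1` gives 1.2 nM.
compound 2 `CC(C)CCCN(C(=O)[C@@H]1C[C@H]1c1ccccc1)c1ccc(-c2ccccc2)cc1` gives > 100 nM, which is a limit of the assay, not a number.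
compound 3 `CC[C@H](C)[C@@H](CN(C(=O)[C@@H]1C[C@H]1c1ccccc1)c1ccc(-c2ccccc2)cc1)NC(C)=O` gives 5.8 nM.

Compound 3 carries the higher of the two numbers; compound 1 gives the lower one. For the measured compounds named here, the one step that bears here is an at least 17-fold lower number from compound 2 to compound 3 (1.23 log units; beyond the scatter), a large change in this assay, with compound 2 sitting at the limit of > 100 nM in this assay, at which 1 of the 3 values shown sits.

Compound 4 `NC1(CN(C(=O)[C@@H]2C[C@H]2c2ccccc2)c2ccc(-c3ccccc3)cc2)CCCC1` differs from compound 3 by 1-aminocyclopentyl in place of 1-acetamido-2-methylbutyl on a saturated chain carbon bound to an amide-type nitrogen. A nitrogen-bearing group stays on that chain carbon, as in compound 3 and compound 1, so the expected step is modest, a 1.5-fold lower number from compound 3 to compound 4 (0.16 log units; within the scatter). Compound 4 is estimated at 4 nM, likely between 1 nM and 20 nM.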

Compound 4, half-maximal effective concentration: 0.57 nM
For compound 4 the middle estimate is 7.0-fold (0.85 log units) above the measured one, and the stated range ends above it.
By their numbers in this assay, from the lowest: compound 4; then compound 1; then compound 3. At a limit, above all of these: compound 2.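

In this assay the change brings a 10-fold lower number from compound 3 to compound 4 (1.01 log units; beyond the scatter), so this chain carbon accepts 1-aminocyclopentyl, with fewer heavy atoms and no defined stereocentres, in place of 1-acetamido-2-methylbutyl. Set against isopentyl, the same group gives an at least 170-fold lower number from compound 2 to compound 4 (2.24 log units; beyond the scatter) in this comparison. Compound 2 stands at a limit, not a number: the limit of > 100 nM in this assay, at which 1 of the 4 values shown sits.

The step swaps the acetamido group for a free amine and the open chain for a ring at once, and the compounds shown do not pull these two changes apart. As far as these compounds go, whether the ring or the amine carries the gain stays open, and 1-acetamidocyclopentyl or an open 1-amino-2-methylbutyl chain would separate them.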